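The source may hold more compounds than are shown below. What is called first, only, known or untested is meant among the compounds shown, and "the series" means these compounds.

Three compounds have been measured in an assay on isolated protein for inhibition of Nitric oxide synthase, inducible (Homo sapiens), with a stated time of 30 min; a higher number here means a weaker inhibitor, a lower number a stronger inhibitor:

compound 1 `Cc1cc(N)nc(CC(C)F)c1` gives 220 nM
compound 2 `Cc1cc(N)nc(CC(C)O)c1` gives 1780 nM
compound 3 `Cc1cc(N)nc(CC(C)CCF)c1` gives 731 nM

Compound 3 holds the second highest of the three numbers. Its nearest neighbour is compound 2, separated by a 2.4-fold lower number from compound 2 to compound 3 (0.39 log units; beyond the scatter), and its furthest is compound 1, separated by a 3.3-fold higher number from compound 1 to compound 3 (0.52 log units; beyond the scatter).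

Compound 4 `CSCCC(C)Cc1cc(C)cc(N)n1` is not yet measured. It differs from compound 3 by methylsulfanyl in place of fluoro on a saturated chain carbon, four bonds along the chain from an aromatic carbon. Within the data shown here, no measured step exchanges fluoro for methylsulfanyl, so the evidence is indirect. Among the measured compounds shown here, two steps bear on it loosely: a 3.3-fold higher number from compound 1 to compound 3 (0.52 log units; beyond the scatter) shows that adding heavy atoms to the chain at this carbon weakened inhibition, and an 8.1-fold higher number from compound 1 to compound 2 (0.91 log units; beyond the scatter) shows that replacing fluoro at such a carbon with another small group also weakened it. Both steps were modest and pointed the same way. The present change again removes the fluoro and adds heavy atoms to the chain, so a modest step toward a higher number in this assay is expected, though it may not clear the scatter.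

Compound 4 is therefore estimated at 1100 nM, with a range from 350 nM to 3500 nM. The expected step is a 1.5-fold higher number from compound 3 to compound 4 (0.18 log units; within the scatter).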

Compound 4, half-maximal inhibitory concentration: > 5000 nM
Compound 4: no number, only a limit; the forecaster's own chance of this, stated with the estimate: 3%; middle value at least 4.5-fold (0.65 log units) from the limit.
By their numbers in this assay, from the lowest: compound 1; then compound 3; then compound 2. At a limit, above all of these: compound 4.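

In this assay compound 4 reaches only a limit of the assay, not a number: the limit of > 5000 nM in this assay, at which 1 of the 4 values shown sits. Methylsulfanyl in place of fluoro on a saturated chain carbon, four bonds along the chain from an aromatic carbon, gives an at least 6.8-fold higher number from compound 3 to compound 4 (0.83 log units; beyond the scatter), so the group carried on this carbon still matters once the chain is already extended, which the earlier compounds did not show. Set against the shorter chains, the 2-(methylsulfanyl)ethyl group gives an at least 2.8-fold higher number from compound 2 to compound 4 (0.44 log units; beyond the scatter) in place of hydroxy and an at least 22-fold higher number from compound 1 to compound 4 (1.35 log units; beyond the scatter) in place of fluoro, the only step printed as large among these compounds, whereas the 2-fluoroethyl group of compound 3 still gives a measurable number.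

As far as these compounds go, the true size of all three steps stays open while compound 4 is known only as a limit. The compounds shown also do not separate the sulfur from the added chain length, a question on which a methoxy group, an amine or a plain alkyl group in place of the methylsulfanyl would bear.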